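This account rests on a few compounds, and the source may have more. Where it says the series, first, only, none or still open, it means among the compounds named here.

In a functional assay on A549 cells (Homo sapiens) for cytotoxicity, read by MTT assay (on this read-out higher numbers stand for weaker inhibition and lower numbers for stronger inhibition), compound 3 `CCn1cc(C(=O)Nc2cccc([N+](=O)[O-])c2)c(=O)c2cc(F)c(N3CCNC(C)C3)c(F)c21` gives 3240 nM and sits within the scatter of compound 2 `CCn1cc(C(=O)Nc2ccc(Cl)cn2)c(=O)c2cc(F)c(N3CCNC(C)C3)c(F)c21` at 3300 nM on the same read-out. Compound 1 `CCn1cc(-c2nc3ccc([N+](=O)[O-])cc3o2)c(=O)c2cc(F)c(N3CCNC(C)C3)c(F)c21` gives 900 nM and lies beyond the scatter on the lower side of compound 3, which leaves compound 3 in the upper pair of the three numbers.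

Compound 4 `CCn1cc(C(=O)Nc2nccs2)c(=O)c2cc(F)c(N3CCNC(C)C3)c(F)c21` is still unmeasured. The change leading to it is 1,3-thiazol-2-yl in place of 3-nitrophenyl on an amide-type nitrogen and amounts to 1,3-thiazol-2-yl in place of 3-nitrophenyl on an amide-type nitrogen. Among the measured compounds shown here, the only measured exchange on that nitrogen, 3-nitrophenyl in place of 5-chloropyridin-2-yl, is a 1.0-fold lower number from compound 2 to compound 3 (0.01 log units; within the scatter) and so no step beyond the scatter is expected in this assay here, with no direction favoured. For the measured compounds named here, this is a single step, and no measured compound carries 1,3-thiazol-2-yl, so the range is kept wide. The expected step is a 1.1-fold lower number from compound 3 to compound 4 (0.03 log units; within the scatter) on this estimate. Compound 4 is estimated at 3000 nM with an expected range from 1200 nM to 7500 nM on this read-out.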

Compound 4, half-maximal inhibitory concentration: 20200 nM
Estimate against measurement, compound 4: 6.7-fold (0.83 log units) below; the measured number lies above the stated range.
By their numbers in this assay, from the lowest: compound 1; then compounds 3 and 2 (each within the scatter of the next); then compound 4.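

In this assay the exchange to 1,3-thiazol-2-yl gives a 6.2-fold higher number from compound 3 to compound 4 (0.79 log units; beyond the scatter) and a 6.1-fold higher number from compound 2 to compound 4 (0.79 log units; beyond the scatter) on the amide-type nitrogen, so the group at this position can shift the number beyond the scatter. The earlier exchange on the same nitrogen, a 1.0-fold lower number from compound 2 to compound 3 (0.01 log units; within the scatter), showed no such shift, which means the match between 3-nitrophenyl and 5-chloropyridin-2-yl does not extend to every aromatic group here. Nothing measured on these compounds explains the step.

It remains open whether the higher number goes with the five-membered ring, the sulfur or the lower heavy-atom count, as 1,3-thiazol-2-yl is the only such group shown. A plain phenyl, a 1,3-oxazol-2-yl or a 1,3-thiazol-2-yl carrying a carboxylic acid on this nitrogen would help separate these readings.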